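The compounds below may be only part of what the source reports. "The series", "measured", "known", "first", "only" and "open" are said of these compounds alone.

Measured compounds:
compound 1, `CC1=NN(C(=O)c2cc3ccccc3oc2=O)C(=O)C1CNc1ccc(S(N)(=O)=O)cc1`, gives 68.9% in a functional assay on the whole organism for inhibition, with Rattus norvegicus as the target, read by paw edema, with stated times of 1 h and 4 h, at a dose of 0.03 mg/kg by the oral route; on this read-out lower numbers stand for less inhibition and higher numbers for more inhibition at the one dose given (going by the name of the read-out)
compound 2, `CC1=NN(C(=O)c2cc3ccccc3oc2=O)C(=O)C1CNc1ccc(C(=O)O)cc1`, gives 63.6% in this assay

Both compounds share one core and differ only in the group carried on the outer benzene ring. On the numbers shown, compound 2 holds the lower of the two values, but its only neighbour is compound 1, and the step of a number 5.3 percentage points lower from compound 1 to compound 2 (within the scatter) lies within the scatter of repeated measurements, so the two compounds cannot be told apart on this read-out.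

Compound 3, `CC1=NN(C(=O)c2cc3ccccc3oc2=O)C(=O)C1CNc1ccc([N+](=O)[O-])cc1`, has not yet been measured. It differs from compound 2 in one place: nitro in place of carboxy on an aromatic carbon. For the measured compounds named here, the only measured step that bears on this change is the one from compound 1 to compound 2, where a different group was exchanged at the same place on the ring, and that step stayed within the scatter. Because a number 5.3 percentage points lower from compound 1 to compound 2 (within the scatter) was so small, the expectation for compound 3 is a step of similar size, a number 0.6 percentage points lower from compound 2 to compound 3 (within the scatter), not beyond the scatter in either direction. Compound 3 is therefore estimated at 63% in this assay, with a range from 46% to 78%.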

Compound 3, a percentage reported as inhibition, in the whole organism at one dose (the size of the read-out at that dose, not a potency): 61.9%
Compound 3: the middle estimate sits 1.1 percentage points above what was measured; measured number inside the range.
By their numbers in this assay, from the lowest: compounds 3, 2 and 1 (each within the scatter of the next).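

Nitro on this aromatic carbon, para to a large group, gives in this assay a number that sits close to both earlier ones: the exchange for carboxy yields a number 1.7 percentage points lower from compound 2 to compound 3 (within the scatter), and the exchange for sulfamoyl yields a number 7 percentage points lower from compound 1 to compound 3 (within the scatter). Three different groups have now been compared at this one place, and this read-out at this one dose cannot tell them apart, even though the nitro group brings 0 hydrogen-bond donors and 2 hydrogen-bond acceptors where carboxy has 1 of each, so the hydrogen-bond donor of carboxy is not needed to keep the number in this range. No measurement shown here gives a reason for this closeness.

The groups shown all leave this place substituted, so the compounds do not tell whether a bare hydrogen, an amine or a methyl group there would stay in the same range, or whether any group is needed at all. They also leave open whether the three compounds would remain this close at other doses, where a difference hidden at this single dose could appear.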